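A few compounds are considered here, and "the series" means these few. Any claim that something is new, unique, unknown or untested is made for them only; others in the source may bear on it.

Measured compounds in a functional assay on the whole organism (strain Wistar Albino) for inhibition, with Rattus norvegicus as the target, read by paw edema, with a stated time of 3 h, at a dose of 20 mg/kg; on this read-out lower numbers stand for less inhibition and higher numbers for more inhibition at the one dose given (going by the name of the read-out):
Compound 1 `COc1ccc2[nH]cc(Cc3nn4c(Cc5ccc(OC)c(OC)c5)nnc4s3)c2c1` gives 19.1%.
Compound 2 `COc1ccc2[nH]c(C)c(Cc3nn4c(Cc5ccc(OC)c(OC)c5)nnc4s3)c2c1` gives 21.4%.

Within the data shown here, only two compounds have numbers so far. Compound 1 stands at the lower of the two values, and compound 2 sits close to it: the step of a number 2.3 percentage points higher from compound 1 to compound 2 (within the scatter) is within the scatter, so the two compounds cannot be told apart on this read-out. Among the measured compounds shown here, that one step concerns a methyl in place of hydrogen on an aromatic carbon and is the only measured step in the set.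

Compound 3 `COc1ccc(Cc2nnc3sc(Cc4c[nH]c5ccccc45)nn23)cc1OC` has not yet been measured. It differs from compound 1 by hydrogen in place of methoxy on an aromatic carbon. For the measured compounds named here, no measured step touches this change: the one step that exists, from compound 1 to compound 2, alters a different position and was itself within the scatter. Nothing in the data points to a direction, so the plain expectation is that compound 3 stays near compound 1, with the estimated step of a number 1.1 percentage points lower from compound 1 to compound 3 (within the scatter) not expected to exceed the scatter. Compound 3 is therefore estimated at 18%, with a range from 8% to 30%.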

Compound 3, a percentage reported as inhibition, in the whole organism at one dose (the size of the read-out at that dose, not a potency): 28.3%
Compound 3: the middle estimate sits 10.3 percentage points below what was measured; the measured number falls inside the stated range.
By their numbers in this assay, from the lowest: compounds 1, 2 and 3 (each within the scatter of the next).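

In this assay, hydrogen in place of methoxy on an aromatic carbon of the six-membered aromatic ring of carbon only, part of a fused or bridged system of two rings, gives a number 9.2 percentage points higher from compound 1 to compound 3 (within the scatter), so this read-out cannot tell the two compounds apart. Among these compounds, this is the first measured step at this position, and it shows that, at the one dose and time tested, the methoxy group is not required there to keep a number of this size. Like the methyl step elsewhere on the same ring system, a number 2.3 percentage points higher from compound 1 to compound 2 (within the scatter), it gives no direction for the change, and no measurement on hand accounts for the result.

The compounds shown leave open whether another group at this position, such as an amine, a carboxylic acid or a longer chain like butoxy, would give a step beyond the scatter. They also leave open whether hydrogen and methoxy at this position would remain indistinguishable at other doses or at other times after dosing.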